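Swapping phenyl for furan-2-yl on a nucleoside core

The source may report more compounds than this note shows. Statements on the series, on what has been measured and on what is new or still open speak of the compounds shown alone.

Compound 1, `COc1nc(N)nc2c1c(-c1ccccc1)cn2[C@@H]1O[C@H](CO)[C@@H](O)[C@H]1O`, was tested in a functional assay on HCT-116 cells (Homo sapiens), read by MTT assay, with a stated time of 72 h; on this read-out lower numbers stand for stronger inhibition and higher numbers for weaker inhibition. Compound 1 gives only a limit there, > 20000 nM, so no number is known for it. Compound 2, `Nc1nc2c(c(-c3ccco3)cn2[C@@H]2O[C@H](CO)[C@@H](O)[C@H]2O)c(=O)[nH]1`, carries a different core with the same sugar. In this assay compound 2 also gives only a limit, > 20000 nM. Both compounds therefore sit at the limit of > 20000 nM in this assay, at which 2 of the 2 values shown sit, and neither shows measurable inhibition of cell growth.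

Compound 3, `COc1nc(N)nc2c1c(-c1ccco1)cn2[C@@H]1O[C@H](CO)[C@@H](O)[C@H]1O`, has not yet been measured. It differs from compound 1 in one place: furan-2-yl in place of phenyl on an aromatic carbon. For the measured compounds named here, because both known values rest at the limit of > 20000 nM in this assay, at which 2 of the 2 values shown sit, there is no measured step to guide the size of this change. The furan-2-yl group is already present in compound 2, which gives > 20000 nM, so nothing seen so far points toward a gain in inhibition.

The expected step is a step that the limit leaves unreadable from compound 1 to compound 3, which amounts to no change beyond the scatter. Compound 3 is therefore estimated at 30000 nM, with a range from 15000 nM to 100000 nM, and most likely this assay would again report only a limit for it.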

Compound 3, half-maximal inhibitory concentration: > 20000 nM
Compound 3: a limit, no number; the forecaster's own chance of this, stated with the estimate: 85%; the middle value lies beyond the limit too.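

Compound 1 and compound 3 both give only a limit in this assay, so the swap of phenyl for furan-2-yl between them cannot be read as a step of any size. All the compounds shown share one result: the limit of > 20000 nM in this assay, at which 3 of the 3 values shown sit.

The compounds shown leave open whether phenyl and furan-2-yl differ at all in this assay.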